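Hydroxy to methoxy: compound 2 to compound 4

A few compounds are considered here, and "the series" means these few. Any claim that something is new, unique, unknown or untested is made for them only; others in the source may bear on it.

Measured so far:
- Compound 1 (`Cc1ccc(-c2nc3ccccc3s2)cc1NC(=O)c1cc([N+](=O)[O-])c(N(C)C)cc1Cl`): > 25000 nM
- Compound 2 (`O=C(Nc1cccc(-c2nc3ccccc3s2)c1)c1cc([N+](=O)[O-])c(O)cc1Cl`): > 25000 nM
- Compound 3 (`O=C(Nc1ccc(F)c(-c2nc3ccccc3s2)c1)c1cc([N+](=O)[O-])ccc1Cl`): > 25000 nM

Compound 2 gives > 25000 nM in an ADME assay on HEK293 cells (Homo sapiens) for cytotoxicity, with a stated time of 72 h (a lower number here means that less compound is needed, a higher number that more compound is needed for the effect), which is a limit of the assay and not a number. For the measured compounds named here, the readings for compound 1 and compound 3 are limits as well, so the series offers no measured step to work from.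

The next compound is compound 4 (`COc1cc(Cl)c(C(=O)Nc2cccc(-c3nc4ccccc4s3)c2)cc1[N+](=O)[O-]`). The structural change from compound 2 is methyl in place of hydrogen on an oxygen on an aromatic ring, which is hydroxy to methoxy, with methyl in place of hydrogen on an oxygen on an aromatic ring.

No step beyond the scatter is expected in this assay, in either direction, because of the limit of > 25000 nM in this assay, at which 3 of the 3 values shown sit. The expected step is a step that the limit leaves unreadable from compound 2 to compound 4, and the assay will most likely report only a limit again. Compound 4 is estimated at 30000 nM, with an expected range of 15000 nM to 60000 nM.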

Compound 4, half-maximal effective concentration: > 25000 nM
Compound 4 gave a limit, no number (the forecaster's own chance of this, stated with the estimate: 85%); the middle value is on the limit's open side.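

Compound 2 and compound 4 both read as limits in this assay and not as numbers, and no step can be read between them for hydroxy to methoxy. In this assay the compounds shown leave open at what concentration any of them reaches the half-maximal effect.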